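Replacing the methoxy group of compound 3 with carboxy

The compounds below may be only part of what the source reports. "The series", "measured", "known", "first", "only" and "open" are said of these compounds alone.

In a functional assay on P388 cells (Mus musculus) for antiproliferative activity (on this read-out higher numbers stand for weaker inhibition and lower numbers for stronger inhibition), compound 1 `COc1ccc(S(=O)(=O)Nc2cccc3cc[nH]c23)cc1` gives 1.1 ug/mL. Compound 2 `Nc1ccc(S(=O)(=O)Nc2cccc3cc[nH]c23)cc1` gives 14 ug/mL. Compound 3 `COc1ccc(S(=O)(=O)Nc2cccc3c(C#N)c[nH]c23)cc1` gives 0.17 ug/mL, the lowest of the three numbers, which makes it the strongest inhibitor measured so far.

Compound 4 `N#Cc1c[nH]c2c(NS(=O)(=O)c3ccc(C(=O)O)cc3)cccc12` keeps the cyano group of compound 3 but carries carboxy in place of methoxy on an aromatic carbon, para to a large group: carboxy in place of methoxy on an aromatic carbon.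

Going by the values given here, two measured steps bear on this change. The closer one also removes the methoxy group, putting amino in its place: a 13-fold higher number from compound 1 to compound 2 (1.10 log units; beyond the scatter), a large change beyond the scatter. The other, with cyano in place of hydrogen, is a 6.5-fold lower number from compound 1 to compound 3 (0.81 log units; beyond the scatter), a modest change beyond the scatter, and compound 4 retains that cyano group. Among the compounds with values here, no carboxy compound has been measured, so the amino step is only an imperfect guide, and the uncertainty is wide. A large move towards weaker inhibition is still expected, similar in size to that amino step or slightly greater. The expected step is an 18-fold higher number from compound 3 to compound 4 (1.25 log units; beyond the scatter). Compound 4 is estimated at 3 ug/mL, with an expected range of 0.5 ug/mL to 20 ug/mL.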

Compound 4, half-maximal inhibitory concentration: > 100 ug/mL
Compound 4: a limit, no number; the forecaster's own chance of this, stated with the estimate: 10%; middle value at least 33-fold (1.52 log units) from the limit.
By their numbers in this assay, from the lowest: compound 3; then compound 1; then compound 2. At a limit, above all of these: compound 4.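

In this assay, carboxy in place of methoxy on an aromatic carbon, para to a large group, brings an at least 580-fold higher number from compound 3 to compound 4 (2.76 log units; beyond the scatter), so this position, which had already responded to amino in a 13-fold higher number from compound 1 to compound 2 (1.10 log units; beyond the scatter), now shows a second replacement of methoxy that moves towards weaker inhibition. The cyano group, which went with a 6.5-fold lower number from compound 1 to compound 3 (0.81 log units; beyond the scatter), is present in compound 4 and does not keep the number low once carboxy stands at this position. The reading for compound 4 is a limit and not a number, and the step therefore has no upper end: the limit of > 100 ug/mL in this assay, at which 1 of the 4 values shown sits.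

The compounds shown leave open whether any replacement of methoxy at this position keeps the number low, for example a methyl group, a chlorine atom or an ethoxy group, and whether the methyl ester of the carboxylic acid would read differently from carboxy itself. They also leave open how carboxy would read on the core of compound 1, without the cyano group.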